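The source may hold more compounds than are shown below. What is called first, only, known or untested is meant among the compounds shown, and "the series" means these compounds.

Compound 3 `Cc1ccc(S(=O)(=O)N2N=C(c3ccc(-n4ccnc4)cc3)CC2c2ccc(N(C)C)cc2)cc1` stands highest of the three compounds measured here: in a functional assay on MDA-MB-231 cells (Homo sapiens) for inhibition, read by sulforhodamine B assay, tested at 10 uM (a higher number here means more inhibition at the concentration tested (going by the name of the read-out), a lower number less inhibition), compound 3 gives 50.8%. Compound 1 `CC(=O)N1N=C(c2ccc(-n3ccnc3)cc2)CC1c1ccc(N(C)C)cc1` gives 5% in this assay, and compound 2 `CN(C)c1ccc(C2CC(c3ccc(-n4ccnc4)cc3)=NN2C(=O)c2ccc(C(F)(F)F)cc2)cc1` gives 17.9%. The steps of a number 45.8 percentage points higher from compound 1 to compound 3 (beyond the scatter) and a number 32.9 percentage points higher from compound 2 to compound 3 (beyond the scatter) were large, and the step of a number 12.9 percentage points higher from compound 1 to compound 2 (beyond the scatter) modest, yet all three change the group on the ring nitrogen, not the aryl that carries the sulfonyl. Compound 4 `CN(C)c1ccc(C2CC(c3ccc(-n4ccnc4)cc3)=NN2S(=O)(=O)c2ccc([N+](=O)[O-])cc2)cc1` keeps that sulfonyl and differs only in this: nitro in place of methyl on an aromatic carbon. For the measured compounds named here, no measured step touches this position, so the change from (4-methylphenyl)sulfonyl to (4-nitrophenyl)sulfonyl is expected to give a step of about a number 0.8 percentage points lower from compound 3 to compound 4 (within the scatter), within the scatter. Compound 4 is therefore estimated at 50%, between 30% and 70%.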

Compound 4, a percentage reported as inhibition, at one concentration (the size of the read-out at that concentration, not a potency): 41.5%
Compound 4: middle estimate off by 8.5 percentage points, on the high side; low and high end bracket the measured number.
By their numbers in this assay, from the lowest: compound 1; then compound 2; then compounds 4 and 3 (each within the scatter of the next).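

In this assay the swap of methyl for nitro gives a number 9.3 percentage points lower from compound 3 to compound 4 (within the scatter) and so shows that this aromatic carbon accepts either group without a change beyond the scatter. With nitro in place, the sulfonyl compound still stands clear of the two carbonyl compounds, with a number 23.6 percentage points higher from compound 2 to compound 4 (beyond the scatter) and a number 36.5 percentage points higher from compound 1 to compound 4 (beyond the scatter) as its steps, so the gain from the sulfonyl does not depend on the methyl. Nothing here gives a measured reason for these numbers.

Only two groups are shown at this position, so it stays open whether an amine or a carboxylic acid there would hold the number at this level.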